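The source may hold more compounds than are shown below. What is called first, only, known or untested is meant among the compounds shown, and "the series" means these compounds.

Of the compounds shown here, three built on one shared core have been tested in a functional assay on the whole organism (Abdomen, strain Swiss albino) with Mus musculus as the target, with stated times of 10 min and 5 min, at a dose of 30 mg/kg by the oral route; on this read-out lower numbers stand for a weaker effect and higher numbers for a stronger effect at the one dose given. Compound 1 `O=C1C2ON=C(c3cn(-c4ccccc4)nc3-c3ccccc3)C2C(=O)N1c1ccccc1` gives 47.4% in this assay. Compound 2 `CN1C(=O)C2ON=C(c3cn(-c4ccccc4)nc3-c3ccccc3)C2C1=O` differs from compound 1 in a single place, (methyl in place of phenyl on an amide-type nitrogen in a ring), and compound 2 gives 30.6%, a result described by a number 16.8 percentage points lower from compound 1 to compound 2 (beyond the scatter). Compound 3 `CCOc1ccc(-c2nn(-c3ccccc3)cc2C2=NOC3C(=O)N(c4ccccc4)C(=O)C23)cc1` carries a different change relative to compound 1, and compound 3 gives 49.5% in this assay; the measurement reads as a number 2.1 percentage points higher from compound 1 to compound 3 (within the scatter), so the two values cannot be told apart.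

Compound 4 `CCOc1ccc(-c2nn(-c3ccccc3)cc2C2=NOC3C(=O)N(C)C(=O)C23)cc1` has not yet been measured. It stands to compound 3 exactly as compound 2 stands to compound 1: the change is methyl in place of phenyl on an amide-type nitrogen in a ring, the same change, at the same place, that separates compound 1 from compound 2. The two cores differ only in ethoxy in place of hydrogen on an aromatic carbon. Since the values of compound 1 and compound 3 lie within the scatter of each other, the second instance of the change is expected to run much like the first. Because the first instance gave a number 16.8 percentage points lower from compound 1 to compound 2 (beyond the scatter), the step is estimated as a number 17 percentage points lower from compound 3 to compound 4 (beyond the scatter). This rests on one earlier pair only, so the estimate is held with some caution. Compound 4 is therefore expected to give 32.5%, with a likely range from 20% to 45%.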

Compound 4, a percentage reported as activity, at one dose (the size of the read-out at that dose, not a potency): 47.5%
Compound 4: the middle estimate sits 15 percentage points below what was measured; the measured number lies above the stated range.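

In this assay, the swap of methyl in place of phenyl on the amide-type nitrogen does not carry over from one core to the other; with the ethoxy group present it gives a number 2 percentage points lower from compound 3 to compound 4 (within the scatter), and the earlier, larger step is not repeated: the same change on two cores in this assay, a number 16.8 percentage points lower (beyond the scatter) from compound 1 to compound 2 and a number 2 percentage points lower (within the scatter) from compound 3 to compound 4, 14.8 percentage points apart, beyond the scatter of two such steps. Seen from the other side, ethoxy in place of hydrogen on an aromatic carbon gives a number 16.9 percentage points higher from compound 2 to compound 4 (beyond the scatter), so its effect also differs with the group on that nitrogen: the same change on two cores in this assay, a number 2.1 percentage points higher (within the scatter) from compound 1 to compound 3 and a number 16.9 percentage points higher (beyond the scatter) from compound 2 to compound 4, 14.8 percentage points apart, beyond the scatter of two such steps. Across these four compounds the two changes therefore do not simply add up, and a step seen on one core is a poor guide to the same step on the other, but this does not show why, and it rests on one pair per core, read at a single dose that gives no potency.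

On these data alone, only compound 2, at 30.6%, stands apart from the other three, and it remains open whether that is special to the pairing of methyl with a hydrogen in place of ethoxy. An ethyl group, a longer chain or a benzyl group on the nitrogen, or a methoxy group or an amine in place of ethoxy, would show whether the pattern holds beyond these four compounds.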